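The source may hold more compounds than are shown below. What is called first, only, known or untested is meant among the compounds shown, and "the series" means these compounds.

Measured so far in a functional assay on HCT-8 cells (Homo sapiens) for antiproliferative activity, read by MTT assay, with a stated time of 48 h; on this read-out lower numbers stand for stronger inhibition and higher numbers for weaker inhibition:
- compound 1 `COc1ccc(C(=O)c2ccc(OC)c3c2OC(C)(C)C=C3)c(NC(=O)CO)c1`: 230 nM
- compound 2 `COc1ccc(C(=O)c2ccc3c(c2)C=CC(C)(C)O3)c(NC(=O)CN)c1`: 490 nM
- compound 3 `C=C(c1ccc2c(c1)C=CC(C)(C)O2)c1ccc(OC)cc1NC(=O)CO`: 220 nM

Compound 3 at 220 nM and compound 1 at 230 nM lie within the scatter of each other. Compound 2 at 490 nM has a higher number than compound 3, and that gap lies beyond the scatter.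

The next compound, compound 4 `C=C(c1ccc2c(c1)C=CC(C)(C)O2)c1ccc(OC)cc1NC(=O)CNC`, carries methylamino in place of hydroxy on a saturated chain carbon bound to a carbonyl carbon. Among the measured compounds shown here, no measured pair isolates this change, so the evidence is indirect. Compound 2, at 490 nM, has nitrogen rather than hydroxy on that chain, but it also differs from compound 3 elsewhere. A modest rise in the number in this assay is therefore expected, meaning weaker inhibition, and it may not clear the scatter. The expected change is a 1.7-fold higher number from compound 3 to compound 4 (0.24 log units; within the scatter). For compound 4 the estimated value is 380 nM, with an expected range of 160 nM to 900 nM.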

Compound 4, half-maximal inhibitory concentration: 590 nM
The estimate for compound 4 lay 1.6-fold (0.19 log units) below the measured number; the measured number falls inside the stated range.
By their numbers in this assay, from the lowest: compounds 3 and 1 (each within the scatter of the next); then compounds 2 and 4 (each within the scatter of the next).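

In this assay, methylamino in place of hydroxy on a saturated chain carbon bound to a carbonyl carbon gives a 2.7-fold higher number from compound 3 to compound 4 (0.43 log units; beyond the scatter). Among the compounds shown here, this is the first comparison that isolates this change, as compound 2 also differs from compound 3 elsewhere. On the core of compound 3, the hydroxy form therefore gives the stronger inhibition, and the gap lies beyond the scatter, but no measurement shown accounts for it.

Going by these compounds, it remains open whether the step follows from losing the hydroxy or from the methyl carried on the nitrogen; a plain amino group and a dimethylamino group at this place on the same core would separate the two. On these data alone, how a methoxy group or a longer chain bearing hydroxy would fare at this place also remains open.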